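Swapping Isopropyl for Allyl on a Carbamate Nitrogen

This account rests on a few compounds, and the source may have more. Where it says the series, first, only, none or still open, it means among the compounds named here.

Of the compounds shown here, three sharing one core have been tested in an assay on DDT1 cells (Cricetulus griseus) for binding affinity to adenosine receptor A1 (Homo sapiens), read by radioligand binding; on this read-out lower numbers stand for stronger inhibition and higher numbers for weaker inhibition. Compound 1 `CCCCNC(=O)OC[C@H]1OC(n2cnc3c(NC4CCOC4)ncnc32)[C@H](O)[C@@H]1O` gives 1410 nM. Compound 2 `CC(C)NC(=O)OC[C@H]1OC(n2cnc3c(NC4CCOC4)ncnc32)[C@H](O)[C@@H]1O` gives 78 nM, the lowest of the three numbers. Compound 3 `O=C(NC1CCCCC1)OC[C@H]1OC(n2cnc3c(NC4CCOC4)ncnc32)[C@H](O)[C@@H]1O` gives 584 nM. The step of an 18-fold lower number from compound 1 to compound 2 (1.26 log units; beyond the scatter) and the step of a 7.5-fold higher number from compound 2 to compound 3 (0.87 log units; beyond the scatter) both lie beyond the scatter, so compound 2 stands as the strongest binder among the three.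

Compound 4 `C=CCNC(=O)OC[C@H]1OC(n2cnc3c(NC4CCOC4)ncnc32)[C@H](O)[C@@H]1O` differs from compound 2 by a single change: allyl in place of isopropyl on an amide-type nitrogen. The entering allyl has the same count of heavy atoms as the leaving isopropyl and no ring, but it is a straight chain carrying one double bond outside aromatic rings. Among the compounds with values here, the steps that bear on this change are an 18-fold lower number from compound 1 to compound 2 (1.26 log units; beyond the scatter) and a 7.5-fold higher number from compound 2 to compound 3 (0.87 log units; beyond the scatter): moving away from isopropyl, toward the straight butyl chain or toward the ring-bearing cyclohexyl, raised the number each time. A modest rise above compound 2 is therefore expected, a 3.2-fold higher number from compound 2 to compound 4 (0.51 log units; beyond the scatter). Compound 4 is estimated at 250 nM, with a range from 80 nM to 800 nM.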

Compound 4, inhibition constant: 524 nM
For compound 4 the middle estimate is 2.1-fold (0.32 log units) below the measured one; the range from low to high includes it.
By their numbers in this assay, from the lowest: compound 2; then compounds 4 and 3 (each within the scatter of the next); then compound 1.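

With the count of heavy atoms held the same and no ring involved, replacing isopropyl with allyl on an amide-type nitrogen still gives a 6.7-fold higher number from compound 2 to compound 4 (0.83 log units; beyond the scatter) in this assay, so that count alone does not set the number at this position. The straight allyl chain with its double bond also gives a 2.7-fold lower number from compound 1 to compound 4 (0.43 log units; beyond the scatter), while a 1.1-fold lower number from compound 3 to compound 4 (0.05 log units; within the scatter) lies within the scatter, so the allyl and cyclohexyl compounds cannot be ranked against each other, and isopropyl remains the group with the lowest number. Nothing measured here explains why the numbers move.

Cyclopropyl, propyl and tert-butyl on the same amide-type nitrogen remain open. Their numbers could help show whether the advantage of isopropyl extends to other branched or small ring groups.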